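Fluoro gives way to methoxy on compound 3

The source may hold more compounds than are shown below. What is called first, only, known or untested is meant among the compounds shown, and "the series" means these compounds.

compound 1 `FC(F)(F)c1ccc2[nH]c(-c3cn(-c4ccccc4)nc3-c3ccccc3)nc2c1` gives 2660 nM
compound 2 `Cc1ccc2[nH]c(-c3cn(-c4ccccc4)nc3-c3ccc(F)cc3)nc2c1` gives 1120 nM
compound 3 `Cc1cc2nc(-c3cn(-c4ccccc4)nc3-c3ccc(F)cc3)[nH]c2cc1C` gives 27200 nM

All three values come from a functional assay on MCF7 cells (Homo sapiens) for antiproliferative activity, read by MTT assay, with a stated time of 48 h (on this read-out lower numbers stand for stronger inhibition and higher numbers for weaker inhibition), and compound 3 holds the highest number of the three at 27200 nM beyond the scatter from both others. Among the compounds with values here, the only measured step between these compounds is a 24-fold higher number from compound 2 to compound 3 (1.39 log units; beyond the scatter) and it is large. Compound 4 `COc1ccc(-c2nn(-c3ccccc3)cc2-c2nc3cc(C)c(C)cc3[nH]2)cc1` differs from compound 3 by a single change methoxy in place of fluoro on an aromatic carbon which places methoxy in place of fluoro on an aromatic carbon, para to a large group. The large measured step was methyl in place of hydrogen on an aromatic carbon, a different change, so it gives no direct guide here. Within the data shown here, no measured pair compares fluoro with methoxy. No step beyond the scatter is therefore expected in this assay although any drift seems likelier toward a lower number, given compound 3 at 27200 nM at the top of the series. The estimate amounts to an expected 1.5-fold lower number from compound 3 to compound 4 (0.18 log units; within the scatter) and no more. For compound 4 the estimated value is 18000 nM with an expected range from 4000 nM to 60000 nM in all.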

Compound 4, half-maximal inhibitory concentration: 12800 nM
For compound 4 the middle estimate is 1.4-fold (0.15 log units) above the measured one; low and high end bracket the measured number.
By their numbers in this assay, from the lowest: compound 2; then compound 1; then compound 4; then compound 3.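

In this assay, within the data shown here, the change from 4-fluorophenyl to 4-methoxyphenyl gives a 2.1-fold lower number from compound 3 to compound 4 (0.33 log units; beyond the scatter) and is the first measured reading of this place, para to a large group. Among these compounds, the one earlier step, a 24-fold higher number from compound 2 to compound 3 (1.39 log units; beyond the scatter), left fluoro untouched and changed another part of the molecule. The new step shows that the number does respond to the group at this place, though far less than it did to the earlier methyl change. Nothing at hand gives a measured property that would explain this difference between methoxy and fluoro.

On these data alone, whether the same exchange would give a step of this size on compound 2 remains open. So does the effect of an amine, a carboxylic acid or a longer chain such as ethoxy at this place.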